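This account rests on a few compounds, and the source may have more. Where it says the series, first, only, none or still open, it means among the compounds named here.

Measured compounds:

Compound 1 `CC(C)(C)c1cc(NC(=O)Nc2cc(C(F)(F)F)cc(C(F)(F)F)c2)n(-c2ccccc2)n1`: in an assay on isolated protein for inhibition of STE20-like serine/threonine-protein kinase (Homo sapiens), read by thermal shift assay, tested at 10 uM (a lower number here means that the compound stabilises the target less, a higher number that the compound stabilises the target more against heat), compound 1 gives 0 degrees C.
Compound 2 `Cc1cc(C)cc(NC(=O)Nc2cc(C(C)(C)C)nn2-c2ccccc2)c1`: in this assay compound 2 gives 2.4 degrees C.
Compound 3 `Cc1ccc(S(=O)(=O)NC(=O)Nc2cc(C(C)(C)C)nn2-c2ccccc2)cc1`: in this assay compound 3 gives -0.3 degrees C.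

All three compounds share one core, a urea carrying a phenyl-substituted pyrazole with a tert-butyl group, and differ only in the group on the far side of the urea. Among the three numbers, compound 2 stands highest. Its nearest neighbour is compound 1, whose value lies lower by a gap beyond the usual scatter of this assay, and compound 3 lies further away still, also beyond the scatter. So the 3,5-dimethylphenyl group of compound 2 is, on these numbers, the most favourable of the three choices made so far.

Compound 4 `Cc1ccc(NC(=O)Nc2cc(C(C)(C)C)nn2-c2ccccc2)cc1` is the next variation. Its change from compound 2 is 4-methylphenyl in place of 3,5-dimethylphenyl on an amide-type nitrogen. Among the measured compounds shown here, no measured pair isolates a change of this kind, so there is nothing to calibrate it against. A modest drop in this assay seems more likely than a rise, though a result within the scatter of compound 2 would not surprise.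

For compound 4 the expected value in this assay is 1.5 degrees C, with a likely range from 0.2 degrees C to 2.8 degrees C. That estimate corresponds to a step of a number 0.90 degrees C lower from compound 2 to compound 4 (within the scatter).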

Compound 4, shift of the target's melting temperature: 4.6 degrees C
Compound 4: the middle estimate sits 3.1 degrees C below what was measured; measured number outside the range, above it.
By their numbers in this assay, from the lowest: compounds 3 and 1 (each within the scatter of the next); then compound 2; then compound 4.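

Going from 3,5-dimethylphenyl to 4-methylphenyl on the amide-type nitrogen gives a number 2.2 degrees C higher from compound 2 to compound 4 (beyond the scatter) in this assay, so this position responds to where methyl groups sit on the aromatic ring and to how many there are, not only to which kind of group is attached. Compounds 1 and 3 could not show this, as each differs from compound 2 by more than a methyl pattern, while compound 4 shows that a small rearrangement alone can move the number beyond the scatter. Nothing available here explains why the melting temperature shifts further with 4-methylphenyl.

This single change removes two methyl groups and introduces another elsewhere on the ring, so the contribution of each part remains unseparated. Plain phenyl and 3-methylphenyl would help to tell them apart, while 4-ethylphenyl or 4-chlorophenyl would test how much the group at the 4-position matters.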